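A few compounds are considered here, and "the series" means these few. Any claim that something is new, unique, unknown or untested is made for them only; others in the source may bear on it.

Compound 1 `CC#C[C@@H](CC(=O)O)c1ccc(OCc2cccc(-c3ccc(Cl)cc3C)c2)cc1` gives 36 nM in an assay on CHO cells for agonist activity at Free fatty acid receptor 1 (Homo sapiens), read by calcium flux; a lower number here means that less compound is needed, a higher number that more compound is needed for the effect. Compound 2 `Cc1cc(Cl)ccc1-c1cccc(COc2ccc([C@H](CC(=O)O)c3nccn3C)cc2)c1` gives 33 nM. Compound 3 `Cc1nc(-c2ccc(C(F)(F)F)cc2)sc1COc1ccc([C@H](CC(=O)O)c2nccn2C)cc1` gives 73 nM.

Compound 3 carries the highest number of the three, and its gap to each of the other two lies beyond the scatter. Compound 4 `Cc1nc(-c2ccc(C(F)(F)F)cc2)sc1COc1ccc([C@H](CC(=O)O)c2nnnn2C)cc1` differs from compound 3 by a single change: 1-methyl-1H-tetrazol-5-yl in place of 1-methyl-1H-imidazol-2-yl on a saturated chain carbon bound to an aromatic carbon and a saturated chain carbon. Going by the values given here, no measured step replaces one five-membered aromatic ring with another at this place. Among the compounds with values here, the only step at that place, a 1.1-fold lower number from compound 1 to compound 2 (0.04 log units; within the scatter), exchanged a chain for a ring without moving the number beyond the scatter, which suggests the place tolerates variation. The step from compound 3 to compound 4 is therefore expected to be small, a 1.2-fold higher number from compound 3 to compound 4 (0.09 log units; within the scatter), most likely nothing beyond the scatter. Compound 4 is estimated at 90 nM, with a range from 35 nM to 230 nM.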

Compound 4, half-maximal effective concentration: 41 nM
Beside the measured number, compound 4's estimate is 2.2-fold (0.34 log units) above it; measured number inside the range.
By their numbers in this assay, from the lowest: compounds 2, 1, 4 and 3 (each within the scatter of the next, the first and the last beyond it).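

Putting 1-methyl-1H-tetrazol-5-yl in place of 1-methyl-1H-imidazol-2-yl gives a 1.8-fold lower number from compound 3 to compound 4 (0.25 log units; within the scatter). The earlier step at this place exchanged a chain for a ring, whereas this one shows that a five-membered aromatic ring with more hetero atoms and hydrogen-bond acceptors can replace another without a change beyond the scatter. No measurement shown here explains this tolerance.

Going by these compounds, it remains open whether a phenyl ring, an amine or a longer chain would be tolerated at this place. The core of compound 2 also leaves open whether 1-methyl-1H-tetrazol-5-yl would behave the same way there.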